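Chloro added to the hydroxyphenyl ring of compound 3

The compounds below may be only part of what the source reports. "The series", "measured", "known", "first", "only" and "open" are said of these compounds alone.

Measured so far in an ADME assay on NIH3T3 cells (Mus musculus) for cytotoxicity, read by MTT assay, with a stated time of 24 h; a higher number here means a weaker inhibitor, a lower number a stronger inhibitor:
compound 1 `COc1ccc(/C=N/NC(=O)CSc2nnc(-c3ccncc3)o2)cc1` gives 132000 nM
compound 2 `Cc1ccc(/C=N/NC(=O)CSc2nnc(-c3ccncc3)o2)cc1` gives 185000 nM
compound 3 `O=C(CSc1nnc(-c2ccncc2)o1)N/N=C/c1ccccc1O` gives 155000 nM

All three compounds share the same core and differ only in the aromatic ring attached to the carbon with a double bond to nitrogen. Their numbers sit in a narrow band: the step of a 1.2-fold higher number from compound 1 to compound 3 (0.07 log units; within the scatter) and the step of a 1.2-fold lower number from compound 2 to compound 3 (0.08 log units; within the scatter) are both within the scatter, as is the step of a 1.4-fold higher number from compound 1 to compound 2 (0.15 log units; within the scatter). Compound 3 therefore stands together with compounds 1 and 2, not apart from them.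

Compound 4 `O=C(CSc1nnc(-c2ccncc2)o1)N/N=C/c1cc(Cl)ccc1O` is compound 3 with one change: chloro in place of hydrogen on an aromatic carbon. Within the data shown here, no measured pair shows a chloro being added, so the only guide is that swapping methoxy, methyl and hydroxy groups on this ring has left this assay essentially unchanged. A small step is expected, a 1.0-fold lower number from compound 3 to compound 4 (0.01 log units; within the scatter), with no clear direction. Compound 4 is estimated at 150000 nM, within a range of 70000 nM to 320000 nM.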

Compound 4, half-maximal inhibitory concentration: 166000 nM
Estimate against measurement, compound 4: 1.1-fold (0.04 log units) below; low and high end bracket the measured number.
By their numbers in this assay, from the lowest: compounds 1, 3, 4 and 2 (each within the scatter of the next).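

In this assay, chloro on the aromatic carbon para to a hydroxy group adds an atom to this ring instead of swapping one group for another, and it gives a 1.1-fold higher number from compound 3 to compound 4 (0.03 log units; within the scatter). The 5-chloro-2-hydroxyphenyl ring also stays close to the other two rings, with a 1.1-fold lower number from compound 2 to compound 4 (0.05 log units; within the scatter) and a 1.3-fold higher number from compound 1 to compound 4 (0.10 log units; within the scatter), so this position takes a chlorine without the number leaving the band set by compound 1, compound 2 and compound 3. Nothing measured here offers an explanation for this flat result.

On these data alone, all four compounds lie within the scatter of one another, so it stays open whether any group on this ring can shift the number. An amine or a carboxylic acid on the same carbon, or a change in the shared core, could show whether this cytotoxicity reading moves at all.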